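Gastric solubility notes: tert-butyl to 3-chlorophenyl on the carbonyl

This account rests on a few compounds, and the source may have more. Where it says the series, first, only, none or still open, it means among the compounds named here.

Three compounds carry values in an ADME assay on stomach for solubility, in simulated gastric fluid; on this read-out lower numbers stand for lower solubility and higher numbers for higher solubility. Compound 1 `Cc1cnc(C(=O)N2CCC3(CC2)CN(C(=O)Nc2ccc(OC(F)(F)F)cc2)CCO3)cn1` gives 91 ug/mL, compound 2 `O=C(Nc1ccc(OC(F)(F)F)cc1)N1CCOC2(CCN(C(=O)c3ccccc3F)CC2)C1` gives 71 ug/mL and compound 3 `CC(C)(C)C(=O)N1CCC2(CC1)CN(C(=O)Nc1ccc(C(F)(F)F)cc1)CCO2` gives 76 ug/mL. Compound 3 stands second highest of the three; its nearest neighbour is compound 2 and its furthest is compound 1, and both gaps lie within the scatter, so the three numbers cannot be ranked against one another. Compound 4 `O=C(Nc1ccc(C(F)(F)F)cc1)N1CCOC2(CCN(C(=O)c3cccc(Cl)c3)CC2)C1` differs from compound 3 by 3-chlorophenyl in place of tert-butyl on a carbonyl carbon. For the measured compounds named here, the only measured step at the same carbonyl carbon, a 1.3-fold lower number from compound 1 to compound 2 (0.11 log units; within the scatter), exchanges one aromatic ring for another and stays within the scatter; no measured step exchanges tert-butyl for an aromatic ring. Compound 2, carrying 2-fluorophenyl on that carbonyl carbon, gives 71 ug/mL, which is the closest guide available. A step no larger than the scatter is therefore expected, a 1.5-fold lower number from compound 3 to compound 4 (0.18 log units; within the scatter). Compound 4 is estimated at 50 ug/mL, with a range of 20 ug/mL to 120 ug/mL.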

Compound 4, solubility: 26 ug/mL
Compound 4: the middle estimate sits 1.9-fold (0.28 log units) above what was measured; the measured number falls inside the stated range.
By their numbers in this assay, from the lowest: compound 4; then compounds 2, 3 and 1 (each within the scatter of the next).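

In this assay the exchange at the carbonyl carbon shows a 2.9-fold lower number from compound 3 to compound 4 (0.47 log units; beyond the scatter) and so lies beyond the scatter, whereas the exchange of one aromatic ring for another at this carbon shows a 1.3-fold lower number from compound 1 to compound 2 (0.11 log units; within the scatter) and does not. This position is therefore not indifferent to its group, at least for 3-chlorophenyl in place of tert-butyl. Nothing available explains the modest step.

Still open, as far as these compounds go, is whether the chlorine or the aromatic ring carries the step. Also open, from the compounds shown here alone, is how a chain ending in an amine or a carboxylic acid would read at this carbon.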